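Notes on replacing the aryl group of compound 2

This account rests on a few compounds, and the source may have more. Where it says the series, first, only, none or still open, it means among the compounds named here.

Compound 2 `Cc1cc(-c2ccc(F)cc2)nnc1N1CCN(c2ncccn2)CC1` gives 76300 nM in a functional assay on BV-2 cells (Mus musculus) for inhibition, read by ELISA, with a stated time of 16 h (on this read-out higher numbers stand for weaker inhibition and lower numbers for stronger inhibition), the highest of the two numbers here; compound 1 `COc1cccc(-c2cc(C)c(N3CCN(c4ncccn4)CC3)nn2)c1` gives 2600 nM. Among the compounds with values here, the single measured step, a 29-fold higher number from compound 1 to compound 2 (1.47 log units; beyond the scatter), changes the group on this same aromatic carbon. Compound 3 `Cc1cc(-c2ccsc2)nnc1N1CCN(c2ncccn2)CC1` differs from compound 2 by thiophen-3-yl in place of 4-fluorophenyl on an aromatic carbon. Within the data shown here, no measured pair covers thiophen-3-yl; the step into compound 2 only shows that this position moves the numbers strongly. For compound 3 a moderate downward step in this assay is expected, a 3.8-fold lower number from compound 2 to compound 3 (0.58 log units; beyond the scatter), with wide uncertainty. Compound 3 is estimated at 20000 nM, between 4000 nM and 100000 nM.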

Compound 3, half-maximal inhibitory concentration: 2400 nM
Compound 3: the middle estimate sits 8.3-fold (0.92 log units) above what was measured; the whole stated range lies above it.
By their numbers in this assay, from the lowest: compounds 3 and 1 (each within the scatter of the next); then compound 2.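

In this assay the aryl position accepts a five-membered ring: thiophen-3-yl in place of 4-fluorophenyl gives a large drop in the number (a 32-fold lower number from compound 2 to compound 3 (1.50 log units; beyond the scatter)). Thiophen-3-yl and 3-methoxyphenyl cannot be told apart (a 1.1-fold lower number from compound 1 to compound 3 (0.03 log units; within the scatter)), so among these three compounds the low number needs no six-membered ring, and compound 2 alone stands apart. No measurement on hand accounts for this difference.

Still open, from the compounds shown here alone, is whether plain phenyl, without the fluorine, sits with compound 2 or with compound 3. Also open, going by these compounds, is how this carbon responds to a non-aromatic group such as cyclohexyl, an amine or a carboxylic acid.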